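The compounds below may be only part of what the source reports. "The series", "measured", "known", "first", "only" and "open" are said of these compounds alone.

Compound 1 `Cc1cccnc1-c1ccc(C(=O)Nc2ccc(Cl)cc2)cc1` gives 2020 nM in a functional assay for antagonist activity at transient receptor potential cation channel subfamily V member 1 (Rattus norvegicus); a lower number here means a stronger inhibitor, a higher number a weaker inhibitor.
Compound 2 `CC(C)(C)c1ccc(NC(=O)c2ccc(-c3ncccc3C#N)cc2)cc1` gives 13 nM in this assay.

Of the two measured numbers, compound 2 holds the lower one, and compound 1 the higher, a gap beyond the usual scatter. Compound 3 `CC(C)(C)c1ccc(NC(=O)c2ccc(-c3ncccc3-c3ncc[nH]3)cc2)cc1` has not yet been measured in this assay. It differs from compound 2 in one place: 1H-imidazol-2-yl in place of cyano on an aromatic carbon. Within the data shown here, no step between measured compounds isolates a change of this kind, so the expectation rests on compound 2 alone. A moderate step toward a higher number is expected: a 4.6-fold higher number from compound 2 to compound 3 (0.66 log units; beyond the scatter). Compound 3 is estimated at 60 nM, within the range 10 nM to 400 nM.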

Compound 3, half-maximal inhibitory concentration: 694 nM
Compound 3: middle estimate off by 12-fold (1.06 log units), on the low side, outside the stated range (above it).
By their numbers in this assay, from the lowest: compound 2; then compound 3; then compound 1.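

Putting 1H-imidazol-2-yl in place of cyano on this aromatic carbon gives, in this assay, a 53-fold higher number from compound 2 to compound 3 (1.73 log units; beyond the scatter), a large step. With the rest of the molecule held fixed, this shows that the activity depends strongly on which group occupies this position. Nothing available here explains the loss. The compounds shown leave open how an amine, a carboxylic acid or a 1-methylimidazol-2-yl group would fare on the same carbon. They also leave open whether the hydrogen on the imidazole nitrogen matters to the size of this step.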